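The source may report more compounds than this note shows. Statements on the series, on what has been measured and on what is new or still open speak of the compounds shown alone.

In a functional assay on HepG2 cells (Homo sapiens) for antiproliferative activity, read by sulforhodamine B assay, with a stated time of 48 h (a higher number here means a weaker inhibitor, a lower number a stronger inhibitor), the measured compounds read as follows

compound 1 `COc1cccc(/C=C/C(=O)C(=Cc2ccc(F)cc2)C(=O)/C=C/c2cccc(OC)c2OC)c1OC`: 580 nM
compound 2 `COc1cccc(C=C(C(=O)/C=C/c2cccc(OC)c2OC)C(=O)/C=C/c2cccc(OC)c2OC)c1OC`: 230 nM
compound 3 `COc1ccc(OC)c(/C=C/C(=O)C(=Cc2ccc(O)c(OC)c2)C(=O)/C=C/c2cc(OC)ccc2OC)c1`: 340 nM

The value of compound 3 lies within the scatter of those of both compound 1 and compound 2. Compound 4 `COc1ccc(OC)c(/C=C/C(=O)C(=Cc2ccc(OC)c(OC)c2)C(=O)/C=C/c2cc(OC)ccc2OC)c1` differs from compound 3 by methyl in place of hydrogen on an oxygen on an aromatic ring, which is methyl in place of hydrogen on an oxygen on an aromatic ring, turning 4-hydroxy-3-methoxyphenyl to 3,4-dimethoxyphenyl. Among the measured compounds shown here, no measured step makes this hydroxy to methoxy change. For the measured compounds named here, the only measured step, a 2.5-fold lower number from compound 1 to compound 2 (0.40 log units; beyond the scatter), is modest and concerns a different exchange, 2,3-dimethoxyphenyl in place of 4-fluorophenyl, so it bears only loosely. No step beyond the scatter is therefore expected in this assay, in either direction. The estimated step is a 1.2-fold lower number from compound 3 to compound 4 (0.07 log units; within the scatter) and no larger. Compound 4 is expected at 290 nM (estimated range 120 nM to 680 nM).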

Compound 4, half-maximal inhibitory concentration: 260 nM
The estimate for compound 4 lay 1.1-fold (0.05 log units) above the measured number, within the range that was stated.
By their numbers in this assay, from the lowest: compounds 2, 4, 3 and 1 (each within the scatter of the next, the first and the last beyond it).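

The hydroxy to methoxy change, from 4-hydroxy-3-methoxyphenyl to 3,4-dimethoxyphenyl, in this assay gives a 1.3-fold lower number from compound 3 to compound 4 (0.12 log units; within the scatter) and so shows that methyl in place of hydrogen on this oxygen leaves the number within the scatter. Among the compounds shown here, the earlier compounds held no exchange at this oxygen, so this is the first reading of the position. No measured evidence accounts for the result. The compounds shown leave open whether an amine or a carboxylic acid here, or a longer chain on this oxygen, would stay within the scatter of compound 3.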